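Methylethenyl in Place of Methoxy on the Aromatic Carbon

This account rests on a few compounds, and the source may have more. Where it says the series, first, only, none or still open, it means among the compounds named here.

compound 1 `Cc1cccc(C)c1OC(C)C1=NCCN1`: 182 nM
compound 2 `CC(Oc1ccccc1Br)C1=NCCN1`: 355 nM
compound 3 `COc1ccccc1OC(C)C1=NCCN1`: 871 nM

In an assay on CHO cells for displacement of a labelled ligand from Alpha-2B adrenergic receptor (Homo sapiens) (a lower number here means a stronger inhibitor, a higher number a weaker inhibitor), compound 3 gives the highest of the three numbers; compound 2 stands nearest to it and compound 1 furthest. Compound 4 `C=C(C)c1ccccc1OC(C)C1=NCCN1` differs from compound 3 in one place: 1-methylethenyl in place of methoxy on an aromatic carbon. For the measured compounds named here, the one measured step that bears on this change is a 2.5-fold higher number from compound 2 to compound 3 (0.39 log units; beyond the scatter), in which methoxy in place of bromo raised the number. Compound 4 moves the other way, exchanging the methoxy for a group of carbon only, and compound 1, which also carries carbon-only groups, gives a lower number than compound 3. A lower number is therefore expected for compound 4, and the step is estimated as a 2.7-fold lower number from compound 3 to compound 4 (0.43 log units; beyond the scatter). The estimate for compound 4 is 320 nM, between 110 nM and 950 nM.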

Compound 4, inhibition constant: 871 nM
Compound 4: middle estimate off by 2.7-fold (0.43 log units), on the low side; the range from low to high includes it.
By their numbers in this assay, from the lowest: compounds 1 and 2 (each within the scatter of the next); then compounds 3 and 4 (each within the scatter of the next).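

In this assay, 1-methylethenyl in place of methoxy on the aromatic carbon gives no change at the digits printed from compound 3 to compound 4 (within the scatter) and so, at this position, a group of carbon only does not separate from the methoxy group. The bromo group does separate from it, with 1-methylethenyl in its place giving a 2.5-fold higher number from compound 2 to compound 4 (0.39 log units; beyond the scatter) in the same direction as a 2.5-fold higher number from compound 2 to compound 3 (0.39 log units; beyond the scatter) for methoxy in its place. Nothing available explains why the methoxy and 1-methylethenyl groups match here. As far as these compounds go, whether an amine or a carboxylic acid at this position would hold the number at this level remains open.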